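Phenyl for Ethyl on the Carbamate Oxygen

This account rests on a few compounds, and the source may have more. Where it says the series, first, only, none or still open, it means among the compounds named here.

Three carbamates built on a shared core have been measured in an ADME assay on BEAS-2B cells (Homo sapiens) for cytotoxicity, read by MTT assay, with a stated time of 72 h; a lower number here means a stronger inhibitor of growth, a higher number a weaker inhibitor of growth. Compound 1 `C=CCOC(=O)Nc1ccc([Se]C#N)cc1` gives 47400 nM. Compound 2 `CCCOC(=O)Nc1ccc([Se]C#N)cc1` gives 46300 nM, and compound 3 `CCOC(=O)Nc1ccc([Se]C#N)cc1` gives 46900 nM. The steps between them are all negligible: a 1.0-fold lower number from compound 1 to compound 3 (0.00 log units; within the scatter), a 1.0-fold higher number from compound 2 to compound 3 (0.01 log units; within the scatter), and a 1.0-fold lower number from compound 1 to compound 2 (0.01 log units; within the scatter). Compound 3 therefore sits indistinguishably among the three, with compound 1 its nearest neighbour and compound 2 its furthest, both within the scatter.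

Compound 4 `N#C[Se]c1ccc(NC(=O)Oc2ccccc2)cc1` has not yet been measured. (phenyl in place of ethyl on an oxygen next to a carbonyl group). Among the compounds with values here, none of the measured steps brings a ring onto the oxygen next to the carbonyl group; the three steps that did alter the group there, vinyl to ethyl, vinyl to methyl, and methyl to hydrogen on the chain, all stayed within the scatter. The data thus offer no basis for predicting a shift beyond the scatter. On that ground compound 4 is expected to differ from compound 3 by a 1.1-fold lower number from compound 3 to compound 4 (0.05 log units; within the scatter) in this assay, a step no larger than the measured ones. The estimate for compound 4 is 42000 nM, with a range from 20000 nM to 90000 nM.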

Compound 4, concentration for total growth inhibition: 38200 nM
For compound 4 the middle estimate is 1.1-fold (0.04 log units) above the measured one; the range from low to high includes it.
By their numbers in this assay, from the lowest: compounds 4, 2, 3 and 1 (each within the scatter of the next).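

Within the data shown here, the oxygen next to a carbonyl group now carries a ring, which none of the earlier compounds had there: phenyl, one six-membered aromatic ring of carbon only with 6 heavy atoms, enters where ethyl with 2 heavy atoms leaves, and this assay records a 1.2-fold lower number from compound 3 to compound 4 (0.09 log units; within the scatter) for this change. The comparisons with the other two groups read the same way, with a 1.2-fold lower number from compound 2 to compound 4 (0.08 log units; within the scatter) for phenyl in place of propyl and a 1.2-fold lower number from compound 1 to compound 4 (0.09 log units; within the scatter) for phenyl in place of allyl, so among these four compounds the saturated chains, the allyl group and the phenyl ring on this oxygen cannot be told apart in this read-out. No measurement bearing on this result is available to explain it.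

Still open is whether a phenyl ring carrying an amine or a carboxylic acid, or a much longer chain on the same oxygen, would also stay within the scatter of these compounds. The four compounds also cannot say whether this flat picture would hold if the nitrile on the shared core were replaced by another group.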